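The source may hold more compounds than are shown below. What is called first, only, known or untested is meant among the compounds shown, and "the series" means these compounds.

Measured in a functional assay for inhibition, with Rattus norvegicus as the target; a lower number here means a stronger inhibitor, a higher number a weaker inhibitor:
- compound 1 `CC(/N=c1\c(O)c(O)\c1=N/c1ccc(C#N)cc1)C(C)(C)C`: 520 nM
- compound 2 `CC(C)(C)C/N=c1\c(O)c(O)\c1=N/c1ccc(C#N)cc1`: > 30000 nM, a limit
- compound 3 `CCCCCCC/N=c1\c(O)c(O)\c1=N/c1ccc(C#N)cc1`: > 30000 nM, a limit

Compound 3 gives no number, only a limit, and it stands at the limit of > 30000 nM in this assay, at which 2 of the 3 values shown sit. Compound 4 `C[C@H](/N=c1\c(O)c(O)\c1=N/c1ccc(C#N)cc1)c1ccccc1` has not yet been measured. It differs from compound 3 as follows: 1-phenylethyl in place of heptyl on a double-bonded nitrogen. In words, 1-phenylethyl stands in place of heptyl on a double-bonded nitrogen.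

For the measured compounds named here, two measured steps bear on this change. They are an at least 57-fold higher number from compound 1 to compound 2 (1.76 log units; beyond the scatter) and an at least 57-fold higher number from compound 1 to compound 3 (1.76 log units; beyond the scatter), both large and beyond the scatter. The third, a step that the two limits leave unreadable from compound 2 to compound 3, cannot be read. Compound 1 alone gives a number, and its 1,2,2-trimethylpropyl, like 1-phenylethyl, has a methyl on the saturated carbon bound to the double-bonded nitrogen. Going by the values given here, a large step to a lower number in this assay is therefore expected, though no measured compound carries 1-phenylethyl. The expected change is an at least 20-fold lower number from compound 3 to compound 4 (1.30 log units; beyond the scatter). For compound 4 the estimated value is 1500 nM, with an expected range from 200 nM to 15000 nM.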

Compound 4, half-maximal inhibitory concentration: > 30000 nM
Compound 4 gave a limit, no number; the forecaster's own chance of this, stated with the estimate: 25%; middle value at least 20-fold (1.30 log units) away from the limit.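

In this assay, the methyl on the saturated carbon bound to the double-bonded nitrogen proves insufficient on its own: 1-phenylethyl carries it too, yet the result is an at least 57-fold higher number from compound 1 to compound 4 (1.76 log units; beyond the scatter). Among the compounds shown, only the 1,2,2-trimethylpropyl of compound 1 gives a number, and here the six-membered aromatic ring of 1-phenylethyl does not take the place of its tert-butyl end. The steps from compound 2 and from compound 3 to compound 4 cannot be read, and the series now gathers at a single limit: the limit of > 30000 nM in this assay, at which 3 of the 4 values shown sit.

As far as these compounds go, it remains open whether the mirror-image form of 1-phenylethyl would give a number, and whether 1-cyclohexylethyl or isopropyl would do so. Compounds 2, 3 and 4 cannot be ranked against one another.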